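Swapping the ring on the amine: from oxane to cyclohexane

The source may report more compounds than this note shows. Statements on the series, on what has been measured and on what is new or still open speak of the compounds shown alone.

Measured so far:
- compound 1 `CN1CCN(c2ncc(-c3ccc4c(NC5CCOCC5)ccnc4c3)cn2)CC1`: 50%
- compound 2 `CN1CCN(c2ncc(-c3ccc4c(NCC5CCOCC5)ccnc4c3)cn2)CC1`: 47%

In an ADME assay on a cell-free system (plasma, Homo sapiens) for protein binding, using equilibrium dialysis, with a stated time of 18 h, compound 2 gives 47%, the highest unbound fraction of the two measured compounds, with compound 1 at 50%. Compound 3 `CN1CCN(c2ncc(-c3ccc4c(NC5CCCCC5)ccnc4c3)cn2)CC1` differs from compound 2 as follows: cyclohexyl in place of (oxan-4-yl)methyl on a nitrogen on an aromatic ring. Within the data shown here, the only measured step, a 1.1-fold higher unbound fraction from compound 1 to compound 2 (0.03 log units; within the scatter), concerns a different change and stays within the scatter, so no measured step bears directly on the change to compound 3. The binding of compound 3 is therefore estimated with wide uncertainty, as a step of a 1.8-fold lower unbound fraction from compound 2 to compound 3 (0.25 log units; within the scatter) towards more binding, giving an expected value of 70% with a range from 48% to 88%.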

Compound 3, plasma protein binding: 85%
Compound 3: the middle estimate sits 2.0-fold (0.30 log units) (unbound fraction) above what was measured, within the range that was stated.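

In this assay the group on this nitrogen proves to matter: a 3.3-fold lower unbound fraction from compound 1 to compound 3 (0.52 log units; beyond the scatter) comes with cyclohexyl in place of oxan-4-yl, and a 3.5-fold lower unbound fraction from compound 2 to compound 3 (0.55 log units; beyond the scatter) comes with cyclohexyl in place of (oxan-4-yl)methyl. Both steps lie beyond the scatter, unlike the step between the two oxane compounds, so among these three compounds the ring of carbon only goes with more binding. Nothing available explains this shift.

Still open, from the compounds shown here alone, is how cyclohexylmethyl would compare with cyclohexyl. Also open, going by these compounds, is how a ring carrying an amine, such as piperidin-4-yl, would compare with oxan-4-yl.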